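This account rests on a few compounds, and the source may have more. Where it says the series, first, only, none or still open, it means among the compounds named here.

Measured in a functional assay on ECa-109 cells for antiproliferative activity against ECa-109 cell line (Homo sapiens), read by MTT assay, with a stated time of 48 h; on this read-out lower numbers stand for stronger inhibition and higher numbers for weaker inhibition:
- compound 1 `COc1ccc(CN(C(=O)CSc2ccccn2)c2cc(OC)c(OC)c(OC)c2)cc1`: 16000 nM
- compound 2 `COc1ccc(CN(C(=O)CSC2=CN=NC2C)c2cc(OC)c(OC)c(OC)c2)cc1`: > 80000 nM, a limit of the assay and not a number
- compound 3 `COc1ccc(CN(C(=O)CSc2nnnn2C)c2cc(OC)c(OC)c(OC)c2)cc1`: 5540 nM

Compound 3 holds the lowest number in the set, with a 2.9-fold lower number from compound 1 to compound 3 (0.46 log units; beyond the scatter). Compound 4 `COc1ccc(CN(C(=O)CSc2nncs2)c2cc(OC)c(OC)c(OC)c2)cc1` is the next to be read. The change is 1,3,4-thiadiazol-2-yl in place of 1-methyl-1H-tetrazol-5-yl on a sulfur: 1,3,4-thiadiazol-2-yl in place of 1-methyl-1H-tetrazol-5-yl, on a sulfur whose other neighbour is a saturated chain carbon.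

All three measured steps sit at this same sulfur, though none is this exact swap. The closest guide is the step between two aromatic rings, a 2.9-fold lower number from compound 1 to compound 3 (0.46 log units; beyond the scatter), which is modest. The larger steps, an at least 5.0-fold higher number from compound 1 to compound 2 (0.69 log units; beyond the scatter) and an at least 14-fold lower number from compound 2 to compound 3 (1.15 log units; beyond the scatter), both involve the non-aromatic ring of compound 2, which compound 4 does not carry. A small change is therefore expected, leaning towards a higher number. The estimated step is a 1.6-fold higher number from compound 3 to compound 4 (0.21 log units; within the scatter). For compound 4 the expected value is 9000 nM, with an estimated range of 2500 nM to 30000 nM.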

Compound 4, half-maximal inhibitory concentration: 9840 nM
The estimate for compound 4 lay 1.1-fold (0.04 log units) below the measured number; low and high end bracket the measured number.
By their numbers in this assay, from the lowest: compounds 3, 4 and 1 (each within the scatter of the next, the first and the last beyond it). At a limit, above all of these: compound 2.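

A third aromatic ring on this sulfur, and the first with a sulfur in the ring, gives steps within the scatter in this assay on both sides, a 1.8-fold higher number from compound 3 to compound 4 (0.25 log units; within the scatter) and a 1.6-fold lower number from compound 1 to compound 4 (0.21 log units; within the scatter) in the opposite direction, so compound 4 cannot be ordered against compound 3 or compound 1. The non-aromatic ring stays apart from this aromatic ring too, with an at least 8.1-fold lower number from compound 2 to compound 4 (0.91 log units; beyond the scatter) on this sulfur, and none of compounds 1, 3 and 4 goes against that split. The entry for compound 2 is a limit of the assay and not a number: the limit of > 80000 nM in this assay, at which 1 of the 4 values shown sits.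

The compounds shown leave open how 1,3,4-oxadiazol-2-yl, with oxygen as the ring atom in place of sulfur, would read here. Also open, as far as these compounds go, is what a primary amine or carboxylic acid on a longer chain on this sulfur would give.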